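A few compounds are considered here, and "the series" means these few. Any claim that something is new, unique, unknown or untested is made for them only; others in the source may bear on it.

Of the compounds shown here, three have so far been measured in a functional assay on U-87MG ATCC cells for antiproliferative activity against U-87 MG (Homo sapiens), read by MTT assay, with a stated time of 48 h, tested at 100 uM; a lower number here means a stronger effect, a higher number a weaker effect of the compound at the concentration tested. Compound 1 `COc1ccc(-c2nc(C)c(C(=O)CSc3nc(-c4ccc(OC)cc4)c(C#N)c(=O)[nH]3)s2)cc1` gives 11.5% in this assay, compound 2 `COc1ccc(-c2nc(SCC(=O)c3sc(-c4ccc(Cl)cc4)nc3C)[nH]c(=O)c2C#N)cc1` gives 16.6%, and compound 3 `Cc1nc(-c2ccc(Cl)cc2)sc1C(=O)CSc1nc(N)c(C#N)c(-c2ccc(Cl)cc2)n1` gives 1.65%. Compound 1 and compound 2 share one core and differ only by methoxy in place of chloro on an aromatic carbon; this change made a step of a number 5.1 percentage points lower from compound 2 to compound 1 (within the scatter). Compound 3 stands on a second core, and the difference between the two cores is not broken down here; its value lies within the scatter of that of compound 1 and beyond the scatter from that of compound 2. Compound 4 `COc1ccc(-c2nc(SCC(=O)c3sc(-c4ccc(Cl)cc4)nc3C)nc(N)c2C#N)cc1` has not yet been measured. It differs from compound 3 by methoxy in place of chloro on an aromatic carbon, the same change at the same place as before. For compound 4 a step of a number 2.4 percentage points higher from compound 3 to compound 4 (within the scatter) is expected, because the same change earlier gave a number 5.1 percentage points lower from compound 2 to compound 1 (within the scatter) on the other core. Compound 4 is accordingly estimated at 4%, expected to fall between 0% and 15%.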

Compound 4, a percentage reported as activity, at one concentration (the size of the read-out at that concentration, not a potency): 0.79%
Estimate against measurement, compound 4: 3.2 percentage points above, within the range that was stated.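

In this assay, the change from 4-chlorophenyl to 4-methoxyphenyl on the second core gave a number 0.9 percentage points lower from compound 3 to compound 4 (within the scatter). Set beside the earlier step, the change does not separate the two cores: the same change on two cores in this assay, a number 5.1 percentage points lower (within the scatter) from compound 2 to compound 1 and a number 0.9 percentage points lower (within the scatter) from compound 3 to compound 4, 4.2 percentage points apart, within the scatter of two such steps. This shows that on these two pairs the change made no step beyond the scatter on either core, but two pairs cannot show that the same would hold on any further core.

The compounds shown leave open what a carboxylic acid, a hydroxy group or a longer alkoxy chain would do in place of the chloro or methoxy on that aromatic carbon.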